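The compounds below may be only part of what the source reports. "The series", "measured", "known", "first", "only" and "open" are said of these compounds alone.

Of the compounds shown here, two sharing one core have been measured in an in vitro functional assay on SH-SY5Y cells for agonist activity at Neuronal acetylcholine receptor; alpha3/beta4 (Homo sapiens), read by FLIPR and calcium flux; a lower number here means that less compound is needed, a higher number that more compound is needed for the effect. Compound 1 `Clc1ccc(C2=CC3CNCC(C2)C3)cn1` gives 16 nM. Compound 2 `C1=C(c2cncc(Oc3ccccc3)c2)CC2CNCC1C2` gives 23 nM, and these two numbers lie within the usual scatter of each other, so neither can be called the more potent. Compound 3 `CC(C)Oc1cncc(C2=CC3CNCC(C2)C3)c1` differs from compound 2 in one place: isopropyl in place of phenyl on an oxygen on an aromatic ring. Among the compounds with values here, no measured pair shows this change, so its effect is not known from the data. The expected step of a 1.7-fold higher number from compound 2 to compound 3 (0.24 log units; within the scatter) is modest, toward a somewhat higher number, and may not exceed the scatter. Compound 3 is estimated at 40 nM, with a likely range from 10 nM to 160 nM.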

Compound 3, half-maximal effective concentration: 69 nM
Beside the measured number, compound 3's estimate is 1.7-fold (0.24 log units) below it; low and high end bracket the measured number.
By their numbers in this assay, from the lowest: compounds 1 and 2 (each within the scatter of the next); then compound 3.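

Replacing phenyl with isopropyl on this oxygen gives a 3.0-fold higher number from compound 2 to compound 3 (0.48 log units; beyond the scatter). This shows that the group on the oxygen does influence the number, although the step is modest and compound 3 still gives a measurable effect without a second aromatic ring. Nothing available explains why the number rises. From the compounds shown here alone, it remains open whether a cyclohexyl group on this oxygen, a carbon ring that is not aromatic, would give a number closer to that of compound 2 or compound 3. A smaller methyl group is equally untested here.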